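Methoxy for hydroxy on the urea and amide pair

A few compounds are considered here, and "the series" means these few. Any claim that something is new, unique, unknown or untested is made for them only; others in the source may bear on it.

Measured so far:
- compound 1 `O=C(Nc1cccc(-n2cc(-c3ccncc3)c(-c3cc(O)cc(Cl)c3)n2)c1)Nc1ccc(Cl)c(C(F)(F)F)c1`: -30.6%
- compound 2 `COc1cc(Cl)cc(-c2nn(-c3cccc(NC(=O)Nc4ccc(Cl)c(C(F)(F)F)c4)c3)cc2-c2ccncc2)c1`: -27.5%
- compound 3 `O=C(Nc1cccc(-n2cc(-c3ccncc3)c(-c3cc(O)cc(Cl)c3)n2)c1)c1cc(C(F)(F)F)cc(C(F)(F)F)c1`: 3.15%

In a functional assay on SR cells (Homo sapiens) for inhibition, read by sulforhodamine B assay, with a stated time of 48 h, tested at 10 uM (a higher number here means a weaker effect of the compound at the concentration tested, a lower number a stronger effect), compound 1 gives -30.6% and compound 2 gives -27.5%. The change between them is methyl in place of hydrogen on an oxygen on an aromatic ring, and the step is a number 3.1 percentage points higher from compound 1 to compound 2 (within the scatter). Compound 3 gives 3.15% in this assay, a number beyond the scatter from both compound 1 and compound 2; the difference between the two cores is not broken down here.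

Compound 4 `COc1cc(Cl)cc(-c2nn(-c3cccc(NC(=O)c4cc(C(F)(F)F)cc(C(F)(F)F)c4)c3)cc2-c2ccncc2)c1` carries the same change on the core of compound 3: methyl in place of hydrogen on an oxygen on an aromatic ring. Because the step of a number 3.1 percentage points higher from compound 1 to compound 2 (within the scatter) stayed within the scatter, the step from compound 3 to compound 4 is expected to be small as well, a number 2.9 percentage points higher from compound 3 to compound 4 (within the scatter). Compound 4 is therefore estimated at 6% in this assay, with the expected range running from -10% to 20%.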

Compound 4, a percentage reported as activity, at one concentration (the size of the read-out at that concentration, not a potency): 41%
Beside the measured number, compound 4's estimate is 35 percentage points below it; the measured number lies above the stated range.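

In this assay, replacing hydroxy with methoxy gives a number 37.9 percentage points higher from compound 3 to compound 4 (beyond the scatter), a clear weakening of the effect at the tested concentration. The size of this step does not carry over from one core to the other: the same change on two cores in this assay, a number 3.1 percentage points higher (within the scatter) from compound 1 to compound 2 and a number 37.9 percentage points higher (beyond the scatter) from compound 3 to compound 4, 34.8 percentage points apart, beyond the scatter of two such steps
This shows that the step depends on the core for these two pairs, but with one pair per core it gives no general rule for other cores and does not show which part of the core accounts for the gap.

Open, as far as these compounds go, is whether an ethoxy group or an amine on that ring position would follow the same core-dependent pattern. Also open, from the compounds shown here alone, is which difference between the cores goes with the gap, the urea against the amide or the other aryl group.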